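Moving the fluorine on the saturated ring carbon of compound 1

The source may report more compounds than this note shows. Statements on the series, on what has been measured and on what is new or still open speak of the compounds shown alone.

Compound 1 `NS(=O)(=O)c1ccc(N2N=C(c3ccc(OCc4ccccc4)cc3)CC2c2ccc(F)cc2)cc1`: > 100000 nM
Compound 2 `NS(=O)(=O)c1ccc(N2N=C(c3ccc(Oc4ccccc4)cc3)CC2c2ccc(F)cc2)cc1`: 33000 nM
Compound 3 `NS(=O)(=O)c1ccc(N2N=C(c3ccccc3)CC2c2ccccc2Cl)cc1`: 44000 nM

Of the compounds shown here, three sharing one core have been measured in an ADME assay on MT4 cells (Homo sapiens) for cytotoxicity, read by MTT assay, with a stated time of 96 h; a higher number here means that more compound is tolerated, a lower number that less compound is tolerated. For compound 1 the value is only a limit of the assay, > 100000 nM, with no number inside it (the limit of > 100000 nM in this assay, at which 1 of the 3 values shown sits). Among the measured compounds shown here, compound 2 gives 33000 nM, and the single step from compound 1 to compound 2 is an at least 3.0-fold lower number from compound 1 to compound 2 (0.48 log units; beyond the scatter), where phenyl replaces benzyl on the oxygen on an aromatic ring. For the measured compounds named here, compound 3 gives 44000 nM; no single-point step connects it to compound 1.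

Compound 4 `NS(=O)(=O)c1ccc(N2N=C(c3ccc(OCc4ccccc4)cc3)CC2c2cccc(F)c2)cc1` has not been measured. It differs from compound 1 only in that (3-fluorophenyl in place of 4-fluorophenyl on a saturated ring carbon). Going by the values given here, none of the measured steps touches the group on the saturated ring carbon, so no step bears directly on this change; the one measured step concerns a different part of the molecule. With compound 1 sitting at the limit and nothing indicating that shifting the fluorine within that ring alters tolerance, compound 4 is expected to remain near compound 1, so that the expected step from compound 1 to compound 4 is a number no higher from compound 1 to compound 4 (the limit leaves the size open), not clearly beyond the scatter. Compound 4 is therefore estimated at 100000 nM, within a range from 40000 nM to 250000 nM.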

Compound 4, half-maximal cytotoxic concentration: 65000 nM
The estimate for compound 4 lay 1.5-fold (0.19 log units) above the measured number, within the range that was stated.
By their numbers in this assay, from the lowest: compounds 2, 3 and 4 (each within the scatter of the next). At a limit, above all of these: compound 1.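

This is the only step shown that touches the group on the saturated ring carbon: with 3-fluorophenyl in place of 4-fluorophenyl, this assay gives an at least 1.5-fold lower number from compound 1 to compound 4 (0.18 log units; that floor lies within the scatter). Compound 4 gives 65000 nM, which supplies a real number for a compound that keeps the benzyl on the oxygen on an aromatic ring. The size printed for the step is only a floor, and the true size of the step stays unread, because compound 1 stands at a limit of the assay: the limit of > 100000 nM in this assay, at which 1 of the 4 values shown sits.

The compounds shown leave open whether moving the fluorine changes tolerance at all, since the floor of this single step does not clear the scatter and no second pair tests the same change. Also open, as far as these compounds go, is how this assay would respond to a methoxy group, an amine or a carboxylic acid in place of the fluorine on this phenyl ring, or to a phenyl ring with no fluorine on this carbon while the benzyl stays on the oxygen.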